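Extending the amide of compound 3: an expected tolerance

This account rests on a few compounds, and the source may have more. Where it says the series, first, only, none or still open, it means among the compounds named here.

Going by the values given here, three related compounds have numbers so far. In an ADME assay on MT4 cells (Homo sapiens) for cytotoxicity, read by MTT assay (a lower number here means that less compound is tolerated, a higher number that more compound is tolerated), compound 3 (`NC(=O)c1[nH]c2ccc(Cl)cc2c1S(=O)(=O)c1c(Cl)cccc1Cl`) gives 16000 nM. That lies within the scatter of compound 2 (`Cc1cc(C)cc(S(=O)(=O)c2c(C(=O)Nc3ccncc3)[nH]c3ccc(Cl)cc23)c1`) at 20200 nM, while compound 1 (`Cc1cc(C)cc(S(=O)(=O)c2c(C(=O)NCc3ccccc3)[nH]c3ccc(Cl)cc23)c1`) stands clearly higher at 38000 nM.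

The unmeasured compound 4 (`O=C(NCc1ccncc1)c1[nH]c2ccc(Cl)cc2c1S(=O)(=O)c1c(Cl)cccc1Cl`) keeps everything in compound 3 except the amide: (pyridin-4-yl)methyl in place of hydrogen on an amide-type nitrogen. In short, (pyridin-4-yl)methyl takes the place of hydrogen on an amide-type nitrogen.

Among the compounds with values here, no measured step matches this change directly. The nearest evidence is a 1.9-fold lower number from compound 1 to compound 2 (0.27 log units; within the scatter), where pyridin-4-yl replaces benzyl on an amide-type nitrogen. Compounds 1 and 2 both carry a substituted amide, but they also differ from compound 3 outside the amide, so they are only a loose guide. With compound 2 at 20200 nM as the closer example, no step beyond the scatter is expected in this assay, with any drift more likely upward. The estimated move is a 1.3-fold higher number from compound 3 to compound 4 (0.10 log units; within the scatter). The expected value for compound 4 is 20000 nM, with an estimated range from 9000 nM to 45000 nM.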

Compound 4, half-maximal cytotoxic concentration: > 50200 nM
Compound 4 ended at the assay's limit; the forecaster's own chance of this, stated with the estimate: 15%; at least 2.5-fold (0.39 log units) between middle value and limit.
By their numbers in this assay, from the lowest: compounds 3, 2 and 1 (each within the scatter of the next, the first and the last beyond it). At a limit, above all of these: compound 4.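

Compound 3 carries only hydrogen on its amide-type nitrogen, and in this assay placing (pyridin-4-yl)methyl there gives an at least 3.1-fold higher number from compound 3 to compound 4 (0.49 log units; beyond the scatter). The one earlier step at this nitrogen, a 1.9-fold lower number from compound 1 to compound 2 (0.27 log units; within the scatter), exchanged one substituent for another and stayed within the scatter, so this is the first change at this position shown to move the number beyond the scatter, and it moves it towards more compound being tolerated. The value of compound 4 is a limit and not a number: the limit of > 50200 nM in this assay, at which 1 of the 4 values shown sits.

The compounds shown cannot separate the contribution of the ring nitrogen from that of the ring itself or of the single carbon linking it to the amide, and the same core carrying a plain benzyl, a pyridin-4-yl set directly on the nitrogen, or the longer 2-(pyridin-4-yl)ethyl chain would begin to tell these apart. From the compounds shown here alone, it also remains open whether a small methyl on this nitrogen would shift the number at all, or whether a chain ending in an amine or a carboxylic acid would behave like the (pyridin-4-yl)methyl group.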